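The source may hold more compounds than are shown below. What is called first, only, known or untested is meant among the compounds shown, and "the series" means these compounds.

Values in a functional assay on HL-60 cells (Homo sapiens) for cytotoxicity, read by MTT assay; on this read-out higher numbers stand for weaker inhibition and lower numbers for stronger inhibition:
- compound 1 `Cc1ccccc1S(=O)(=O)NC(C)C1=CC(=O)c2c(O)ccc(O)c2C1=O`: 70 nM
- compound 2 `COc1ccc(S(=O)(=O)NC(C)C2=CC(=O)c3c(O)ccc(O)c3C2=O)cc1`: 20 nM
- compound 3 `COc1ccc(S(=O)(=O)NC(C)C2=CC(=O)c3c(O)ccc(O)c3C2=O)c(OC)c1`: 500 nM

Compound 2 has the lowest number of the three, and its gaps to both others lie beyond the scatter. The next step leads to compound 4 `CCOC(=O)c1ccc(S(=O)(=O)NC(C)C2=CC(=O)c3c(O)ccc(O)c3C2=O)cc1`, with ethoxycarbonyl in place of methoxy on an aromatic carbon, para to a large group (ethoxycarbonyl in place of methoxy on an aromatic carbon).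

For the measured compounds named here, no measured step places ethoxycarbonyl on the series, so the evidence is indirect. The closest guides are the other changes on the same aromatic ring. One is a 3.5-fold lower number from compound 1 to compound 2 (0.54 log units; beyond the scatter), a modest step. Another is a 7.1-fold higher number from compound 1 to compound 3 (0.85 log units; beyond the scatter), also modest. The third is a 25-fold higher number from compound 2 to compound 3 (1.40 log units; beyond the scatter), a large step and the only one that keeps the 4-methoxyphenyl framework while adding one group. These steps show that the number in this assay can move substantially with changes on this ring, in either direction. Compound 2 at 20 nM is the lowest so far, so a rise seems more likely than a further fall. A modest rise is expected, though no change beyond the scatter remains possible.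

The expected change is a 3.5-fold higher number from compound 2 to compound 4 (0.54 log units; beyond the scatter). For compound 4 the estimated value is 70 nM, with an expected range of 15 nM to 300 nM.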

Compound 4, half-maximal inhibitory concentration: 120 nM
Beside the measured number, compound 4's estimate is 1.7-fold (0.23 log units) below it; the measured number falls inside the stated range.
By their numbers in this assay, from the lowest: compound 2; then compounds 1 and 4 (each within the scatter of the next); then compound 3.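

In this assay, the exchange of methoxy for ethoxycarbonyl on an aromatic carbon, para to a large group, gives a 6.0-fold higher number from compound 2 to compound 4 (0.78 log units; beyond the scatter). This is the first step shown that swaps the group at this place while the rest of the molecule stays the same, and it shows that the low number of compound 2 does not survive this exchange, although the step is rated modest rather than large. The data hold nothing measured that would account for this rise.

The compounds shown leave open whether the rise belongs to the ester as a whole or to some part of it, since a carboxylic acid, a methyl ester and a primary amide do not appear at this place, and neither does a simple ethyl or a longer alkoxy chain. They also leave open how a compound with hydrogen at this place and no other group on the ring would stand against compound 2 and compound 4, and whether a smaller group such as fluorine or a hydroxyl would hold the number near that of compound 2.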